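This account rests on a few compounds, and the source may have more. Where it says the series, first, only, none or still open, it means among the compounds named here.

Measured so far: compound 1 `O=C(Nc1cc(-c2ccccc2)nn1-c1ccccc1)c1ccccc1Cl` gives 2500 nM in an assay on CHO cells with metabotropic glutamate receptor 5 (Homo sapiens) as the target; a lower number here means that less compound is needed, a higher number that more compound is needed for the effect; compound 2 `O=C(Nc1cc(-c2ccccc2)nn1-c1ccccc1)c1cccc(Cl)c1` gives 40 nM; compound 3 `O=C(Nc1cc(-c2ccccc2)nn1-c1ccccc1)c1ccccc1O` gives only a limit, > 10000 nM, which is the assay limit (the limit of > 10000 nM in this assay, at which 1 of the 3 values shown sits).

Compound 1 stands at the highest number of the two numbers measured; its nearest neighbour is compound 2, reached by a 63-fold lower number from compound 1 to compound 2 (1.80 log units; beyond the scatter). Compound 3 lies beyond the limit after an at least 4.0-fold higher number from compound 1 to compound 3 (0.60 log units; beyond the scatter).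

Compound 4 `Cc1cccc(C(=O)Nc2cc(-c3ccccc3)nn2-c2ccccc2)c1` differs from compound 1 by 3-methylphenyl in place of 2-chlorophenyl on a carbonyl carbon. Among the compounds with values here, the change mirrors the 3-chlorophenyl in place of 2-chlorophenyl step, which was a 63-fold lower number from compound 1 to compound 2 (1.80 log units; beyond the scatter) in this assay; no measured pair compares methyl with chloro. A large lowering is therefore expected, somewhat short of that step: a 25-fold lower number from compound 1 to compound 4 (1.40 log units; beyond the scatter). Compound 4 is estimated at 100 nM (range 25 nM to 500 nM).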

Compound 4, half-maximal effective concentration: 90 nM
Compound 4: the middle estimate sits 1.1-fold (0.05 log units) above what was measured; measured number inside the range.
By their numbers in this assay, from the lowest: compound 2; then compound 4; then compound 1. At a limit, above all of these: compound 3.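

In this assay, the lowering is not confined to 3-chlorophenyl: 3-methylphenyl in place of 2-chlorophenyl gives a 28-fold lower number from compound 1 to compound 4 (1.44 log units; beyond the scatter). Methyl and chloro are still not interchangeable on this aromatic carbon, with a 2.3-fold higher number from compound 2 to compound 4 (0.35 log units; beyond the scatter). Replacing 2-hydroxyphenyl gives an at least 110-fold lower number from compound 3 to compound 4 (2.04 log units; beyond the scatter) and this is only a bound, as the starting value is a limit: the limit of > 10000 nM in this assay, at which 1 of the 4 values shown sits.

Open, going by these compounds, is whether 3-aminophenyl or 3-carboxyphenyl on the same carbonyl carbon keeps the number low. Also open, on these data alone, is whether a longer chain such as 3-propylphenyl does so.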